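Thiophenylmethyl phenoxyacetamides as TRPM8 agonists: amide nitrogen substituent

The source may report more compounds than this note shows. Statements on the series, on what has been measured and on what is new or still open speak of the compounds shown alone.

Measured compounds:
compound 1 `CCCc1ccc(OCC(=O)N(CC)Cc2cccs2)cc1`, 1810 nM in an assay on HEK293 cells for agonist activity at transient receptor potential cation channel subfamily M member 8 (Homo sapiens), read by fluorescence and calcium flux, with a stated time of 15 min; on this read-out higher numbers stand for an effect only at larger amounts of compound and lower numbers for an effect already at smaller amounts
compound 2 `CCN(Cc1cc[nH]c1)C(=O)COc1ccc(C)cc1`, 21800 nM
compound 3 `Cc1ccc(OCC(=O)N(Cc2cccs2)C(C)C)cc1`, 70 nM

Compound 3 gives the lowest number of the three in this assay. Compound 1 stands nearest to it and still shows a clearly higher number, beyond the scatter; compound 2 lies furthest away, also beyond the scatter. No pair among these three differs in a single place, so the figures say only that the arrangement in compound 3, with isopropyl on the amide-type nitrogen and the thiophene-bearing chain carbon, is the one that acts at the smallest amounts here.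

Compound 4 `Cc1ccc(OCC(=O)N(Cc2cccs2)c2cn[nH]c2)cc1` is not yet measured. It is derived from compound 3 by one change: 1H-pyrazol-4-yl in place of isopropyl on an amide-type nitrogen. Among the compounds with values here, nothing measured here shows what a ring bearing a hydrogen-bond donor and acceptor does in this position; the only comparison with an altered nitrogen substituent, compound 2 against compound 3, also changes the second arm and is therefore not a clean guide.

The expectation is a sizeable loss, a 21-fold higher number from compound 3 to compound 4 (1.33 log units; beyond the scatter), toward higher numbers in this assay. Compound 4 is accordingly estimated at 1500 nM, within a range of 300 nM to 8000 nM.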

Compound 4, half-maximal effective concentration: 1.4 nM
Compound 4: the middle estimate sits 1100-fold (3.03 log units) above what was measured, and the stated range ends above it.
By their numbers in this assay, from the lowest: compound 4; then compound 3; then compound 1; then compound 2.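

In this assay, within the data shown here, 1H-pyrazol-4-yl in place of isopropyl on the amide-type nitrogen gives a 50-fold lower number from compound 3 to compound 4 (1.70 log units; beyond the scatter), a large step beyond the scatter and the first clean single-place comparison. It shows that this position is not limited to a small saturated group: a five-membered aromatic ring with 2 hetero atoms, carrying 1 hydrogen-bond donor and 1 hydrogen-bond acceptor, is accepted here, and compound 4 now has the lowest number of the four in the series. Nothing available explains the size of this step, so it stands as an observation only.

The compounds shown leave open whether the result belongs to this particular ring, since a phenyl ring, a pyridine ring or a pyrazole with a methyl group on its ring nitrogen in the same place would separate the ring itself from the ring's nitrogen hydrogen. Also open, from the compounds shown here alone, is whether 1H-pyrazol-4-yl gives a comparable result on the shared core when the propyl group of compound 1 or a carboxylic acid stands in place of the methyl group of compound 4.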